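This account rests on a few compounds, and the source may have more. Where it says the series, first, only, none or still open, it means among the compounds named here.

Measured so far:
Compound 1 `O=C(NCN1CCC(c2cccc[n+]2[O-])CC1)c1ccc(F)c(Cl)c1` gives 67%
Compound 2 `Cc1cccc(C(=O)NCN2CCC(c3ccccn3)CC2)c1` gives 67%

In a functional assay on HEK293 cells for agonist activity at D(4) dopamine receptor (Homo sapiens), read by FLIPR (on this read-out higher numbers stand for larger maximal responses and lower numbers for smaller maximal responses), compound 2 stands level with compound 1 at the digits shown; the two values lie within the usual scatter, so neither can be called the larger. Compound 3 `Cc1cccc(C(=O)NCN2CCC(c3cccc[n+]3[O-])CC2)c1` has not yet been measured. It differs from compound 2 by a group of 7 heavy atoms (5 carbon, 1 nitrogen, 1 oxygen; one six-membered aromatic ring with 1 hetero atom) in place of a group of 6 heavy atoms (5 carbon, 1 nitrogen; one six-membered aromatic ring with 1 hetero atom), on a saturated ring carbon. Among the compounds with values here, no step between measured compounds that differ in only one place is available. Compound 3 is expected to stay close to compound 2, since compound 1 also carries the entering group and gives 67%. The step of a number 1 percentage points lower from compound 2 to compound 3 (within the scatter) is expected to be none beyond the scatter. For compound 3 the estimate is 66%, with a range from 52% to 80%.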

Compound 3, largest response reached (reported as efficacy), in percent of the reference or control that the assay uses: 77%
Compound 3: the middle estimate sits 11 percentage points below what was measured; the measured number falls inside the stated range.
By their numbers in this assay, from the lowest: compounds 1, 2 and 3 (each within the scatter of the next).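

In this assay, replacing pyridin-2-yl on the saturated ring carbon with the oxygen-bearing ring gives a number 10 percentage points higher from compound 2 to compound 3 (within the scatter) and so shows that this position accepts the exchange without a step beyond the scatter. With that group held fixed, 3-methylphenyl in place of 3-chloro-4-fluorophenyl on the carbonyl carbon gives a number 10 percentage points higher from compound 1 to compound 3 (within the scatter) and also stays within the scatter. No measurement here explains either result. On these data alone, whether the maximal response would hold with a phenyl ring or a carboxylic acid on that saturated ring carbon remains open.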